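This account rests on a few compounds, and the source may have more. Where it says the series, first, only, none or still open, it means among the compounds named here.

Within the data shown here, compound 3 `CC(C)=CCC/C(C)=C/CC1Cc2c(OCCCNC(=O)c3ccco3)cc(=O)n(CCCO)c2CC1(C)C` stands at the top of the three numbers so far: in a functional assay on PANC-1 cells (Homo sapiens) for inhibition, read by MTT assay, with a stated time of 24 h, tested at 10 uM (a lower number here means less inhibition, a higher number more inhibition at the concentration tested (going by the name of the read-out)), compound 3 gives 69.5%, while compound 2 `CC(C)=CCC/C(C)=C/CC1Cc2c(OCCCNS(=O)(=O)c3ccc(Br)cc3)cc(=O)n(CCCO)c2CC1(C)C` gives 15.2% and compound 1 `CC(C)=CCC1Cc2c(OCCCNC(=O)c3ccco3)cc(=O)n(CCCO)c2CC1(C)C` gives 2.1%. The step of a number 67.4 percentage points higher from compound 1 to compound 3 (beyond the scatter) shows how much the 3-methylbut-2-en-1-yl group counts, and the step of a number 54.3 percentage points higher from compound 2 to compound 3 (beyond the scatter) shows that the group on the amine nitrogen counts as well. Compound 4 `CC(C)=CCC/C(C)=C/CC1Cc2c(OC(=O)Nc3ccc(F)cc3F)cc(=O)n(CCCO)c2CC1(C)C` keeps the chain of compound 3 but differs in the side chain on the aromatic oxygen: (2,4-difluorophenyl)carbamoyl in place of 3-(((furan-2-yl)carbonyl)amino)propyl on an oxygen on an aromatic ring. Among the measured compounds shown here, no measured step covers this exchange; only the sensitivity seen in the step from compound 2 to compound 3 hints that such a change is likely large, and a fall is expected in this assay, of about a number 34.5 percentage points lower from compound 3 to compound 4 (beyond the scatter). For compound 4 the expected value is 35%, between 10% and 65%.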

Compound 4, a percentage reported as inhibition, at one concentration (the size of the read-out at that concentration, not a potency): 33.7%
Compound 4: the middle estimate sits 1.3 percentage points above what was measured, within the range that was stated.
By their numbers in this assay, from the lowest: compound 1; then compound 2; then compound 4; then compound 3.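

In this assay the side chain on the oxygen on an aromatic ring proves to count on its own: (2,4-difluorophenyl)carbamoyl in place of 3-(((furan-2-yl)carbonyl)amino)propyl gives a number 35.8 percentage points lower from compound 3 to compound 4 (beyond the scatter), although the two groups hold the same count of heavy atoms. Nothing available explains this fall.

As far as these compounds go, it remains open how a plain phenylcarbamoyl without fluorine would compare with the (2,4-difluorophenyl)carbamoyl of compound 4. Also open, from the compounds shown here alone, is how a longer chain on the oxygen, or an amine or carboxylic acid at its end, would fare against compound 3.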